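Methyl to hydrogen on the pyridinyl ring of an amidinothiosemicarbazide

A few compounds are considered here, and "the series" means these few. Any claim that something is new, unique, unknown or untested is made for them only; others in the source may bear on it.

Of the compounds shown here, three have been measured in a functional assay on A-375 cells (Homo sapiens) for cytotoxicity, read by MTT assay, with a stated time of 72 h, tested at 10 uM; a higher number here means more inhibition of growth at the concentration tested, a lower number less inhibition of growth. Compound 1 `N/C(=N\NC(=S)N1CCOCC1)c1ccc(F)cn1` gives 70.3%, compound 2 `Cc1cccc(/C(N)=N/NC(=S)N2CCCC2)n1` gives 55.9%, and compound 3 `Cc1ccnc(/C(N)=N/NC(=S)N2CCN(c3ccccn3)CC2)c1` gives 76%. On these numbers compound 3 stands where compound 1 comes within the scatter of it, while compound 2 falls short of it by more than the scatter. Within the data shown here, no pair of these differs in only one place, so no single step can be read from them.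

Compound 4 `N/C(=N\NC(=S)N1CCN(c2ccccn2)CC1)c1ccccn1` is not yet measured. It differs from compound 3 in one way: hydrogen in place of methyl on an aromatic carbon. The change is a single carbon without ring, donor or acceptor. He expects that in this assay compound 4 shows a step from compound 3 of a number 4 percentage points lower from compound 3 to compound 4 (within the scatter), within the scatter. His estimate for compound 4 is 72%, with a range from 55% to 85%.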

Compound 4, percent growth inhibition at one concentration: 74.4%
Compound 4: middle estimate off by 2.4 percentage points, on the low side; low and high end bracket the measured number.
By their numbers in this assay, from the lowest: compound 2; then compounds 1, 4 and 3 (each within the scatter of the next).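

In this assay the change from 4-methylpyridin-2-yl to pyridin-2-yl gives a number 1.6 percentage points lower from compound 3 to compound 4 (within the scatter) and so shows that methyl at this place, opposite the ring nitrogen, is not needed for the growth inhibition seen at the concentration tested. Among these compounds, this is the first comparison here of compounds differing in one place, and it rests on this single pair. Nothing available explains the result.

What the compounds shown leave open is whether a larger or different group at this place, such as an ethyl chain, a methoxy group or an amine, would move the number beyond the scatter.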